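Adding a Methyl While Shortening the Chain

This account rests on a few compounds, and the source may have more. Where it says the series, first, only, none or still open, it means among the compounds named here.

In a functional assay on MDA-MB-231 cells (Homo sapiens) for cytotoxicity, read by MTT assay, with a stated time of 72 h (on this read-out lower numbers stand for stronger inhibition and higher numbers for weaker inhibition), compound 1 `O=C1c2c[n+]([O-])c3ccccc3c2C(=O)c2c1c1ccccc1n2CCCCn1ccnc1` gives 210 nM and compound 2 `CN1CCN(CCCCn2c3c(c4ccccc42)C(=O)c2c[n+]([O-])c4ccccc4c2C3=O)CC1` gives 110 nM in a pair that stays within the scatter (a 1.9-fold lower number from compound 1 to compound 2 (0.28 log units; within the scatter)). Compound 3 `O=C1c2c[n+]([O-])c3ccccc3c2C(=O)c2c1c1ccccc1n2CCCCN1CCNCC1` has the highest number of the three at 3310 nM and is therefore the weakest so far.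

Going by the values given here, the next structure is compound 4 `CN1CCN(CCCn2c3c(c4ccccc42)C(=O)c2c[n+]([O-])c4ccccc4c2C3=O)CC1`, which has no measurement yet. The change is 4-methylpiperazin-1-yl in place of (piperazin-1-yl)methyl on a saturated chain carbon, three bonds along the chain from an aromatic nitrogen on a saturated chain carbon, three bonds along the chain from an aromatic nitrogen. Cut further out, it reads 4-(piperazin-1-yl)butyl to 3-(4-methylpiperazin-1-yl)propyl.

The closest evidence is the large methyl step (a 30-fold higher number from compound 2 to compound 3 (1.48 log units; beyond the scatter)). Read backwards, it suggests that compound 4 should regain much of what compound 3 lost. The step to compound 3 from the imidazole compound is also large (a 16-fold higher number from compound 1 to compound 3 (1.20 log units; beyond the scatter)). Among the compounds with values here, no measured step covers the shorter chain, so the range stays wide.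

A large fall in the number is expected (a 19-fold lower number from compound 3 to compound 4 (1.29 log units; beyond the scatter)). Compound 4 is estimated at 170 nM within an expected range of 50 nM to 600 nM in this assay.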

Compound 4, half-maximal inhibitory concentration: 390 nM
For compound 4 the middle estimate is 2.3-fold (0.36 log units) below the measured one, within the range that was stated.
By their numbers in this assay, from the lowest: compounds 2, 1 and 4 (each within the scatter of the next, the first and the last beyond it); then compound 3.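

Going by these compounds alone, with the 4-methylpiperazin-1-yl group kept, shortening the butyl chain to a propyl chain gives the first reading of chain length in this assay, and it costs real ground: a 3.5-fold higher number from compound 2 to compound 4 (0.55 log units; beyond the scatter). Set against an 8.5-fold lower number from compound 3 to compound 4 (0.93 log units; beyond the scatter), which combines the added methyl and the shorter chain, this suggests that among these compounds the shorter chain gives back only part of what the methyl gains. The imidazole compound on its butyl chain and the methylpiperazine on its propyl chain cannot be told apart, a 1.9-fold higher number from compound 1 to compound 4 (0.27 log units; within the scatter), even though they differ in both the end group and the chain.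

Nothing available here explains why chain length matters in this series. As far as these compounds go, how an ethyl or pentyl chain, or a morpholine at the chain end, would behave remains open.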